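This account rests on a few compounds, and the source may have more. Where it says the series, first, only, none or still open, it means among the compounds named here.

For the measured compounds named here, in a functional assay on HCT-116 cells (Homo sapiens) for antiproliferative activity, read by MTT assay, with a stated time of 48 h (a lower number here means a stronger inhibitor, a higher number a weaker inhibitor), compound 3 `COc1ccc(N(C)c2cc(C)nc(C)n2)cc1F` gives 584 nM, the lowest number measured so far, while compound 1 `COc1ccc(N(C)c2ccnc(Cl)n2)cc1[N+](=O)[O-]` gives 4700 nM. Compound 2 `COc1ccc(N(C)c2ccnc(Cl)n2)cc1OCCCCCBr` gives > 10000 nM, which is a limit of the assay and not a number.

Compound 4 `COc1ccc(N(C)c2cc(C)nc(C)n2)cc1O` keeps the rest of compound 3 but has hydroxy in place of fluoro on an aromatic carbon, ortho to a methoxy group: hydroxy in place of fluoro on an aromatic carbon.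

Going by the values given here, only one measured step offers a comparison. Replacing nitro with (5-bromopentyl)oxy on an aromatic carbon gave an at least 2.1-fold higher number from compound 1 to compound 2 (0.32 log units; beyond the scatter). That step is only a lower bound, and it brought in a long chain rather than a single atom, so it says little about this smaller swap. With so little to go on, no clear change beyond the scatter is expected in this assay, and the uncertainty is wide in both directions.

The expected step is a 1.0-fold higher number from compound 3 to compound 4 (0.01 log units; within the scatter). For compound 4 the estimated value is 600 nM. The expected range for compound 4 runs from 120 nM to 3000 nM.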

Compound 4, half-maximal inhibitory concentration: 126 nM
Compound 4: middle estimate off by 4.8-fold (0.68 log units), on the high side; low and high end bracket the measured number.
By their numbers in this assay, from the lowest: compound 4; then compound 3; then compound 1. At a limit, above all of these: compound 2.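

In this assay hydroxy in place of fluoro, ortho to a methoxy group, gives a 4.6-fold lower number from compound 3 to compound 4 (0.67 log units; beyond the scatter) and so shows that this position responds to a change of a single heavy atom. Unlike the earlier step, which brought in a long chain and ended at a limit of the assay, this one has a measured number at both ends, and the entering hydroxy counts as a hydrogen-bond donor and acceptor where fluoro counts as neither. Nothing measured here accounts for why the number falls.

This swap rests on one pair of compounds, so the compounds shown cannot separate the role of the hydroxy group from that of losing fluoro. On these data alone, how an amine or a carboxylic acid would compare at this position stays open, as does whether the same swap would act alike with the chloro-bearing core of compound 1.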